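Nitroaryl sulfone series: working notes, compound 3 to compound 4

This account rests on a few compounds, and the source may have more. Where it says the series, first, only, none or still open, it means among the compounds named here.

Measured so far:
compound 1 `O=C(/C(=C\c1csc([N+](=O)[O-])c1)S(=O)(=O)c1ccc(Br)cc1)c1ccc(Br)cc1`: 1000 nM
compound 2 `COc1ccc(C(=O)/C(=C\c2ccc(O)c([N+](=O)[O-])c2)SCc2ccc(Br)cc2)cc1`: 10000 nM
compound 3 `O=C(/C(=C\c1ccc(Cl)c([N+](=O)[O-])c1)S(=O)(=O)c1ccc(Br)cc1)c1ccc(Br)cc1`: 10000 nM

In a functional assay on DU-145 cells (Homo sapiens) for inhibition, read by trypan blue exclusion, with a stated time of 96 h (a lower number here means a stronger inhibitor of growth, a higher number a weaker inhibitor of growth), compound 3 gives 10000 nM. Compound 3 stands level with compound 2 at the digits shown, and these two together give the highest numbers of the three; the furthest from compound 3 is compound 1, which gives the lower number 1000 nM. Among the compounds with values here, the one single-point step measured in this set is a 10-fold higher number from compound 1 to compound 3 (1.00 log units; beyond the scatter), a modest step beyond the scatter.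

Compound 4 `O=C(/C(=C\c1ccc(Br)c(O)c1)S(=O)(=O)c1ccc(Br)cc1)c1ccc(Br)cc1` has not yet been measured. It differs from compound 3 in one place: 4-bromo-3-hydroxyphenyl in place of 4-chloro-3-nitrophenyl on a double-bonded chain carbon bound to a double-bonded chain carbon. The step from compound 1 to compound 3 concerns the same place on the chain, but it exchanges a thiophene-based group for a phenyl-based group, not one substituted phenyl for another, so it does not bear directly on this change. Compound 2 differs from compound 3 in more than one place, so its value cannot be attributed to any one change. Within the data shown here, no measured step therefore speaks to the move from compound 3 to compound 4, and the expectation is for no step beyond the scatter in this assay.

Compound 4 is accordingly estimated at 10000 nM, with a range of 3000 nM to 30000 nM. The expected step is no change at the digits printed from compound 3 to compound 4 (within the scatter).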

Compound 4, concentration for 50% growth inhibition: 50000 nM
The estimate for compound 4 lay 5.0-fold (0.70 log units) below the measured number, outside the stated range (above it).
By their numbers in this assay, from the lowest: compound 1; then compounds 2 and 3 (each within the scatter of the next); then compound 4.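

Notes on the position: in this assay, exchanging 4-chloro-3-nitrophenyl for 4-bromo-3-hydroxyphenyl on a double-bonded chain carbon bound to a double-bonded chain carbon gives a 5.0-fold higher number from compound 3 to compound 4 (0.70 log units; beyond the scatter) and so shows that one substituted phenyl group cannot simply stand in for another at this place. Within the data shown here, until now, the only step at this place had been the exchange of a thiophene-based group for a phenyl-based group. Among these compounds, the span at this place now reaches a 50-fold higher number from compound 1 to compound 4 (1.70 log units; beyond the scatter) in the same assay, and the two groups carrying a nitro group both give lower numbers than the 4-bromo-3-hydroxyphenyl group, though this holds for only three compounds and no measurement here explains either step.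

The entering group differs from the leaving group in both of its ring substituents, so the compounds shown do not separate the part played by the swap of chlorine for bromine from that played by the swap of nitro for hydroxyl. Also open, as far as these compounds go, is how an amine or a carboxylic acid in place of the nitro group would read in this assay on an otherwise unchanged core.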